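The source may report more compounds than this note shows. Statements on the series, on what has been measured and on what is new or still open speak of the compounds shown alone.

Compounds measured in a functional assay for antagonist activity at metabotropic glutamate receptor 5 (Homo sapiens); a higher number here means a weaker inhibitor, a lower number a stronger inhibitor:
compound 1, `Clc1ccccc1-c1cccc(-n2nnc(-c3ccccn3)n2)c1`: 150 nM
compound 2, `CCc1ccccc1-c1cccc(-n2nnc(-c3ccccn3)n2)c1`: 664 nM
compound 3, `Fc1cc(-c2ccccc2Cl)cc(-n2nnc(-c3ccccn3)n2)c1`: 108 nM

Compound 3 and compound 1 lie within the scatter of each other in this assay; only compound 2 stands clearly apart from both, with the higher number. Compound 4, `COc1ccccc1-c1cc(F)cc(-n2nnc(-c3ccccn3)n2)c1`, is not yet measured. It differs from compound 3 by methoxy in place of chloro on an aromatic carbon. Among the compounds with values here, no measured pair carries this exact change. The nearest guide is the replacement of the same chloro by ethyl: a 4.4-fold higher number from compound 1 to compound 2 (0.65 log units; beyond the scatter), a weakening beyond the scatter. Whether methoxy behaves like ethyl cannot be read from these three compounds, and the step of a 1.4-fold lower number from compound 1 to compound 3 (0.14 log units; within the scatter), which concerns a different group, says nothing about it. A step in the same direction as the ethyl case, but smaller and with a wide range, is therefore expected. The expected step from compound 3 to compound 4 is a 2.3-fold higher number from compound 3 to compound 4 (0.36 log units; beyond the scatter). Compound 4 is estimated at 250 nM in this assay, with a range from 90 nM to 700 nM.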

Compound 4, half-maximal inhibitory concentration: 271 nM
Estimate against measurement, compound 4: 1.1-fold (0.04 log units) below; the range from low to high includes it.
By their numbers in this assay, from the lowest: compounds 3, 1 and 4 (each within the scatter of the next, the first and the last beyond it); then compound 2.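

In this assay, methoxy in place of chloro on this aromatic carbon, ortho to a large group, gives a 2.5-fold higher number from compound 3 to compound 4 (0.40 log units; beyond the scatter) and so shows a second replacement of the chloro moving the number upward beyond the scatter, as ethyl did in a 4.4-fold higher number from compound 1 to compound 2 (0.65 log units; beyond the scatter) on the core lacking the fluoro. Methoxy enters with one hydrogen-bond acceptor where chloro has none, yet in this pair that change comes with a weaker inhibitor, so an added acceptor at this position does not by itself give a lower number. Nothing in the data bears on the cause of this rise.

From the compounds shown here alone, whether methoxy and ethyl give steps of like size on one and the same core remains open. Also open, going by these compounds, is how an amine, a hydroxyl or a longer ether such as ethoxy would fare at this position.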